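The source may report more compounds than this note shows. Statements on the series, on what has been measured and on what is new or still open speak of the compounds shown alone.

The three measured compounds share one core and differ in the aryl group on an aromatic nitrogen. Compound 1 `CC(=O)Nc1ccc(-n2nncc2CN2C(=O)C3(C(C#N)=C(N)Oc4c3c3nc5ccccc5nc3c3ccccc43)c3ccccc32)cc1` was tested in a functional assay on HepG2 cells (Homo sapiens) for antiproliferative activity, read by MTT assay, with a stated time of 48 h; on this read-out lower numbers stand for stronger inhibition and higher numbers for weaker inhibition. In this assay compound 1 reaches only a limit, > 50000 nM. Compound 2 `Cc1ccc(Cl)cc1-n1nncc1CN1C(=O)C2(C(C#N)=C(N)Oc3c2c2nc4ccccc4nc2c2ccccc32)c2ccccc21` likewise gives only a limit in this assay, > 50000 nM. The step that the two limits leave unreadable from compound 1 to compound 2 in this assay therefore cannot be read. Compound 3 `N#CC1=C(N)Oc2c(N)cc3nc4ccccc4nc3c2C12C(=O)N(Cc1cnnn1-c1ccc([N+](=O)[O-])cc1)c1ccccc12` also stands at a limit in this assay, > 50000 nM. All values shown in this assay sit at that limit (the limit of > 50000 nM in this assay, at which 3 of the 3 values shown sit).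

Compound 4 `N#CC1=C(N)Oc2c(N)cc3nc4ccccc4nc3c2C12C(=O)N(Cc1cnnn1-c1c(Cl)cc(Cl)cc1Cl)c1ccccc12` has not yet been measured in this assay. It differs from compound 3 in one place (2,4,6-trichlorophenyl in place of 4-nitrophenyl on an aromatic nitrogen). Within the data shown here, no measured step bears directly on this change, and the only step between measured compounds is unreadable from its two limits. Because the limit of > 50000 nM in this assay, at which 3 of the 3 values shown sit, holds for every measured compound, the step expected in this assay is a number no higher from compound 3 to compound 4 (the limit leaves the size open), nothing beyond the scatter that could be read. Compound 4 is accordingly expected to give an estimated 50000 nM in this assay, in a range from 20000 nM to 100000 nM, most likely again reported only as a limit.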

Compound 4, half-maximal inhibitory concentration: 37800 nM
Beside the measured number, compound 4's estimate is 1.3-fold (0.12 log units) above it; low and high end bracket the measured number.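

In this assay, 2,4,6-trichlorophenyl in place of 4-nitrophenyl on the aromatic nitrogen gives an at least 1.3-fold lower number from compound 3 to compound 4 (0.12 log units; that floor lies within the scatter). Compound 4 is the only compound shown that gives a measured number rather than a limit, 37800 nM, so a change of aryl group at this position can bring a value within the range of the assay. The floor of this step, however, stays within the usual scatter. The remaining compounds give no number to set beside it, and the steps among them cannot be read, leaving compound 4 alone off the limit: the limit of > 50000 nM in this assay, at which 3 of the 4 values shown sit.

Going by these compounds, how large the step from 4-nitrophenyl to 2,4,6-trichlorophenyl really is remains open, since only its floor can be read and compound 3 stands at a limit. The compounds shown also do not tell whether the result depends on all the chlorines of 2,4,6-trichlorophenyl, or how a plain phenyl, a 4-chlorophenyl, a 4-aminophenyl or a 4-carboxyphenyl on the same aromatic nitrogen would read out in this assay.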